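Shared-core esters: step from compound 2 to compound 3

The compounds below may be only part of what the source reports. "The series", "measured", "known", "first", "only" and "open" are said of these compounds alone.

Measured so far:
Compound 1 `CC(C)=CC1C(C(=O)OCC2COCCOCCOCCOCCOCCO2)C1(C)C` gives 63000 nM in a functional assay on HeLa cells (Homo sapiens) for inhibition, read by sulforhodamine B assay, with a stated time of 48 h; a lower number here means a stronger inhibitor of growth, a higher number a weaker inhibitor of growth.
Compound 2 `O=C(CCCc1cc2ccccc2[nH]1)OCC1COCCOCCOCCOCCOCCO1` gives > 100000 nM in this assay, which is a limit of the assay and not a number.

Compound 2 stands at the limit of > 100000 nM in this assay, at which 1 of the 2 values shown sits; of the two measured values one is a number and one is this limit, so all that can be said of the pair is that compound 1 returns a number and compound 2 does not. Compound 3 `O=C(CCCCc1ccccc1)OCC1COCCOCCOCCOCCOCCO1` differs from compound 2 in one place: benzyl in place of 1H-indol-2-yl on a saturated chain carbon, three bonds along the chain from a carbonyl carbon. For the measured compounds named here, no step between two measured compounds is available to size this change in this assay; the only other measured compound, compound 1, carries a different acid part altogether. The expectation is therefore a step of no clear direction beyond the scatter, with a fair chance that compound 3 again returns only a limit. The estimate for compound 3 in this assay is 100000 nM, in the range 40000 nM to 250000 nM. Expected is a number no higher from compound 2 to compound 3 (the limit leaves the size open), that is, little change.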

Compound 3, concentration for 50% growth inhibition: 52000 nM
For compound 3 the middle estimate is 1.9-fold (0.28 log units) above the measured one, within the range that was stated.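

In this assay, the change from 1H-indol-2-yl to benzyl on a saturated chain carbon, three bonds along the chain from a carbonyl carbon, can now be sized from one side only, as an at least 1.9-fold lower number from compound 2 to compound 3 (0.28 log units; that floor lies within the scatter); a real gain in this step is neither shown nor excluded. The value of compound 2 remains a limit of the assay and not a number: the limit of > 100000 nM in this assay, at which 1 of the 3 values shown sits.

For the compounds shown here, the new number also gives the first comparison of two acid parts that both return values: 4-phenylbutyl in place of 2,2-dimethyl-3-(2-methylprop-1-en-1-yl)cyclopropyl on a carbonyl carbon gives a 1.2-fold lower number from compound 1 to compound 3 (0.08 log units; within the scatter), so these two acid parts cannot be told apart in this assay.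

Open, from the compounds shown here alone, is whether any group at this position moves the number beyond the scatter, for example an amine or a carboxylic acid in place of benzyl on that saturated chain carbon, or a longer chain. Also open is what the shared core contributes, since every compound shown carries it unchanged.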